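The compounds below may be only part of what the source reports. "The series", "measured", "known", "first", "only" and "open" are said of these compounds alone.

Working notes on the series.

The shared core of compound 1 `O=C(Nc1ccc(Cl)cc1)Nc1ccc(Oc2ccc(-c3nccs3)cc2)cc1` carries a urea; in a functional assay on A549 cells (Homo sapiens) for inhibition, read by MTT assay and WST assay, with a stated time of 72 h, tested at 10 uM (on this read-out higher numbers stand for more inhibition of growth at the one concentration tested and lower numbers for less inhibition of growth), compound 1 gives 17.7%. Compound 2 `O=C(Nc1ccccc1)Nc1ccc(Oc2ccc(-c3nccs3)cc2)cc1`, the unsubstituted phenyl analogue, has no result in this assay ("not determined" (no result reported)). Compound 3 `O=C(Nc1ccc(Oc2ccc(-c3nccs3)cc2)cc1)Nc1ccc(Cl)c([N+](=O)[O-])c1` gives 77.1% in this assay and thus stands highest of the two numbers available, with compound 1 nearest and well beyond the scatter below it. For the measured compounds named here, the one step that can be read, a number 59.4 percentage points higher from compound 1 to compound 3 (beyond the scatter), is large.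

Compound 4 `O=C(Nc1ccc(Oc2ccc(-c3nccs3)cc2)cc1)Nc1cccc(C(F)(F)F)c1` differs from compound 3 by 3-(trifluoromethyl)phenyl in place of 4-chloro-3-nitrophenyl on an amide-type nitrogen. Going by the values given here, no measured step matches this change directly. Among the compounds with values here, the only step that bears on it is the one from compound 1 to compound 3, which shows how much the nitro group is worth when added; compound 4 has no nitro group, and in addition the chlorine is exchanged for a trifluoromethyl group, for which no comparison exists. Taking the loss of the nitro group as the main guide, a drop in this assay is expected, of size roughly a number 47.1 percentage points lower from compound 3 to compound 4 (beyond the scatter), though the trifluoromethyl exchange leaves the outcome uncertain. Compound 4 is therefore expected to give about 30%, estimated between 10% and 60%.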

Compound 4, percent growth inhibition at one concentration: 71.5%
Beside the measured number, compound 4's estimate is 41.5 percentage points below it; measured number outside the range, above it.
By their numbers in this assay, from the lowest: compound 1; then compounds 4 and 3 (each within the scatter of the next).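

On the amide-type nitrogen, a nitro group is not required for a high reading in this assay: with 3-(trifluoromethyl)phenyl in place of 4-chloro-3-nitrophenyl, the result is a number 5.6 percentage points lower from compound 3 to compound 4 (within the scatter), so this assay does not separate the two groups. Set against the 4-chlorophenyl group, the same 3-(trifluoromethyl)phenyl group gives a number 53.8 percentage points higher from compound 1 to compound 4 (beyond the scatter), which leaves compound 1 as the only one of the three numbers that reads low, with two structurally different groups on the amide-type nitrogen both giving a high reading. Nothing at hand accounts for the two groups reading alike or for the low reading with 4-chlorophenyl.

As far as these compounds go, it remains open whether other groups on this phenyl ring, such as a nitrile, an amine or a carboxylic acid, would stay with compound 3 and compound 4 or fall to the level of compound 1. From the compounds shown here alone, since every reading comes from one concentration, it also remains open whether compound 3 and compound 4 would still fall within the scatter of each other in a full concentration series.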